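Methoxy for chloro: cytotoxicity notes on the series

The compounds below may be only part of what the source reports. "The series", "measured", "known", "first", "only" and "open" are said of these compounds alone.

Compound 1 `O=C(CSc1c[nH]c2cc(Cl)ccc12)Nc1ccc(Cl)c(Cl)c1` is the reference for the open question. In an ADME assay on HEK-293T cells (Homo sapiens) for cytotoxicity, read by CCK-8 assay, with a stated time of 48 h (on this read-out higher numbers stand for lower toxicity in this test and lower numbers for higher toxicity in this test), compound 1 gives 67800 nM. Compound 3 `CCOc1ccccc1NC(=O)CSc1c[nH]c2ccc(Cl)cc12` carries a different amide-side aryl group; in this assay compound 3 gives 37600 nM. How the two cores differ is not broken down here, and the two values sit within the usual scatter of each other. Compound 2 `CCOc1ccccc1NC(=O)CSc1c[nH]c2ccc(OC)cc12` is the methoxy analogue of compound 3, differing by methoxy in place of chloro on an aromatic carbon being applied there as methoxy in place of chloro on an aromatic carbon. In this assay compound 2 reaches > 100000 nM, which is a limit of the assay and not a number (the limit of > 100000 nM in this assay, at which 1 of the 3 values shown sits). This yields an at least 2.6-fold higher number from compound 3 to compound 2 (0.42 log units; beyond the scatter). Compound 4 `COc1ccc2c(SCC(=O)Nc3ccc(Cl)c(Cl)c3)c[nH]c2c1` applies the same change to compound 1. For compound 4 a step of a 2.2-fold higher number from compound 1 to compound 4 (0.34 log units; beyond the scatter) is expected in this assay because the identical change gave an at least 2.6-fold higher number from compound 3 to compound 2 (0.42 log units; beyond the scatter). Compound 4 is therefore expected to give 150000 nM in this assay, between 60000 nM and 400000 nM, most probably again as a limit.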

Compound 4, half-maximal cytotoxic concentration: 78400 nM
The estimate for compound 4 lay 1.9-fold (0.28 log units) above the measured number, within the range that was stated.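

In this assay, methoxy in place of chloro on the core of compound 1 gives a 1.2-fold higher number from compound 1 to compound 4 (0.06 log units; within the scatter), so on this core the change cannot be told apart from repeat-measurement noise. Set beside the earlier step, this neither shows that the change carries across cores with the same size nor shows that its size depends on the core: the same change on two cores in this assay, an at least 2.6-fold higher number (0.42 log units; beyond the scatter) from compound 3 to compound 2 and a 1.2-fold higher number (0.06 log units; within the scatter) from compound 1 to compound 4; the limit leaves it open whether they differ. From the compounds shown here alone, compound 2 gives > 100000 nM, which is a limit of the assay and not a number, so the full size of the step to compound 2 remains unknown.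

The compounds shown leave open whether an amine or a carboxylic acid in place of chloro would shift the number on either core. They also leave open how large the methoxy step on the core of compound 3 really is.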